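Swapping a Methoxyphenyl for a Dimethylphenyl Ring

The source may report more compounds than this note shows. Statements on the series, on what has been measured and on what is new or still open speak of the compounds shown alone.

Measured so far:
compound 1 `O=C(Nc1ccc(Nc2ncnc3c2OCCN3)cc1)Nc1ccc(Cl)c(C(F)(F)F)c1` gives 177 nM
compound 2 `O=C(Nc1ccc(Nc2ncnc3c2OCCN3)cc1)Nc1ccc(C(F)(F)F)cc1` gives 306 nM
compound 3 `COc1ccc(NC(=O)Nc2ccc(Nc3ncnc4c3OCCN4)cc2)cc1` gives 227 nM

These three compounds share one core and differ only in the aromatic ring attached to an amide-type nitrogen. In an assay on isolated protein for inhibition of proto-oncogene tyrosine-protein kinase receptor Ret (Homo sapiens), read by 33P incorporation, with stated times of 15 min and 40 min (a lower number here means a stronger inhibitor, a higher number a weaker inhibitor), compound 1 gives 177 nM, compound 2 gives 306 nM and compound 3 gives 227 nM. On these numbers compound 3 sits between the other two, and its gaps to compound 1 and to compound 2 both lie within the scatter of this assay, so the three cannot be told apart.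

Compound 4 `Cc1cc(C)cc(NC(=O)Nc2ccc(Nc3ncnc4c3OCCN4)cc2)c1` has not yet been measured. It differs from compound 3 in one place: 3,5-dimethylphenyl in place of 4-methoxyphenyl on an amide-type nitrogen. Among the measured compounds shown here, only one measured step bears on a change at this ring: a 1.3-fold lower number from compound 2 to compound 3 (0.13 log units; within the scatter). That step, together with the narrow spread of the three values, suggests this ring can be varied without moving the number beyond the scatter. The same outcome is expected here, so for compound 4 the expected step is a 1.1-fold higher number from compound 3 to compound 4 (0.04 log units; within the scatter). Compound 4 is estimated at 250 nM, with a likely range from 100 nM to 600 nM.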

Compound 4, half-maximal inhibitory concentration: 1070 nM
Estimate against measurement, compound 4: 4.3-fold (0.63 log units) below; the whole stated range lies below it.
By their numbers in this assay, from the lowest: compounds 1, 3 and 2 (each within the scatter of the next); then compound 4.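

The earlier compounds shown here made this ring on the amide-type nitrogen look tolerant of change, but in this assay 3,5-dimethylphenyl in place of 4-methoxyphenyl gives a 4.7-fold higher number from compound 3 to compound 4 (0.67 log units; beyond the scatter) and the replacement of 4-(trifluoromethyl)phenyl gives a 3.5-fold higher number from compound 2 to compound 4 (0.54 log units; beyond the scatter) as well. So the number at this position can move beyond the scatter, even though 4-methoxyphenyl and 4-(trifluoromethyl)phenyl could not be told apart. The swap from compound 3 keeps the count of 8 heavy atoms and the six-membered aromatic ring, and the counted differences are an oxygen replaced by carbon and one hydrogen-bond acceptor lost, yet nothing measured here explains the higher number.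

Two things happen together in this change, the loss of the methoxy group and the arrival of two methyl groups, and no compound shown carries only one of them, so their separate contributions stay open. Also open, on these data alone, is how the number would respond at this ring to a single methyl group, an amine, a carboxylic acid or a longer chain.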